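Lengthening the Side Chain on a Cytotoxic Five-Ring Core

The source may report more compounds than this note shows. Statements on the series, on what has been measured and on what is new or still open speak of the compounds shown alone.

Three compounds have been tested in a functional assay on A549 cells (Homo sapiens) for cytotoxicity, read by MTT assay, with a stated time of 72 h; on this read-out higher numbers stand for weaker inhibition and lower numbers for stronger inhibition:

compound 1 `O=C1c2c[n+]([O-])c3ccccc3c2C(=O)c2c1c1ccccc1n2Cc1cn([C@H]2C[C@H](O)[C@@H](CO)O2)nn1` gives 350 nM
compound 2 `O=C1c2c[n+]([O-])c3ccccc3c2C(=O)c2[nH]c3ccccc3c21` gives 320 nM
compound 3 `CC1(C)OC[C@H](Cn2cc(Cn3c4c(c5ccccc53)C(=O)c3c[n+]([O-])c5ccccc5c3C4=O)nn2)O1` gives 340 nM

Compound 2, the one with a bare hydrogen on the ring nitrogen, stands on the lowest number of the three, but its distance to compound 3 and to compound 1 lies within the scatter, so no order among them can be claimed. Within the data shown here, the one full step known, a 1.0-fold lower number from compound 1 to compound 3 (0.01 log units; within the scatter), swaps one substituent on that nitrogen for another and changes nothing beyond the scatter.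

Compound 4 `CN(C)CCCCCn1c2c(c3ccccc31)C(=O)c1c[n+]([O-])c3ccccc3c1C2=O` differs from compound 2 in one place: 5-(dimethylamino)pentyl in place of hydrogen on an aromatic nitrogen. Among the measured compounds shown here, no measured step places a chain of this kind on the nitrogen, so the only guide is that the three measured compounds, whatever sits on that nitrogen, all cluster together in this assay. On that basis no step beyond the scatter is expected; the estimated step is a 1.1-fold lower number from compound 2 to compound 4 (0.03 log units; within the scatter). Compound 4 is therefore expected to give about 300 nM, somewhere between 100 nM and 900 nM.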

Compound 4, half-maximal inhibitory concentration: 210 nM
Compound 4: middle estimate off by 1.4-fold (0.15 log units), on the high side, within the range that was stated.
By their numbers in this assay, from the lowest: compounds 4, 2, 3 and 1 (each within the scatter of the next).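

Until now, this aromatic nitrogen had carried only hydrogen or side chains containing rings, so compound 4 is the first shown with a ring-free chain there. In this assay, placing 5-(dimethylamino)pentyl on the nitrogen gives a 1.5-fold lower number from compound 2 to compound 4 (0.18 log units; within the scatter) and therefore shows that this position accepts such a chain with no change beyond the scatter. Nothing available shows what the chain does in these cells.

Still open, going by these compounds, is whether the amine or the carbon chain matters more: a plain pentyl chain with no amine, shorter or longer chains carrying the same dimethylamino group, or a carboxylic acid in place of the amine would help to separate the two. On these data alone, whether this tolerance extends to other cell types also remains open.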